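Phenyl to methyl on a nitrogen: two cores compared

The source may report more compounds than this note shows. Statements on the series, on what has been measured and on what is new or still open speak of the compounds shown alone.

Measured compounds in a functional assay on Huh-7 cells (Homo sapiens) for cytotoxicity, read by resazurin assay, with a stated time of 48 h; a higher number here means a weaker inhibitor, a lower number a stronger inhibitor:
compound 1 `CCOc1ccc(NC(=O)c2c(N)n[nH]c2NC)cc1` gives 21800 nM
compound 2 `CCOc1ccc(NC(=O)c2c(N)n[nH]c2Nc2ccccc2)cc1` gives 4320 nM
compound 3 `CCOc1ccc(NC(=O)/C(C#N)=C(\Nc2ccccc2)SC)cc1` gives 25300 nM

Compound 2 and compound 1 differ by methyl in place of phenyl on a nitrogen on an aromatic ring; this change made a 5.0-fold higher number from compound 2 to compound 1 (0.70 log units; beyond the scatter). Compound 3 carries a different core; how the core of compound 3 differs from the core of compound 2 is not broken down here. Compound 4 `CCOc1ccc(NC(=O)/C(C#N)=C(\NC)SC)cc1` is not yet measured; it differs from compound 3 by methyl in place of phenyl on an amine nitrogen. The two places are not the same: in compound 2 the nitrogen sits on an aromatic ring with aromatic carbon as its other neighbour, in compound 3 it is an amine nitrogen with a double-bonded chain carbon as its other neighbour, so this is the same kind of change, not the same change. Since compound 3 already stands highest of the three, with compound 1 within the scatter of it, the step is expected to be a 3.2-fold higher number from compound 3 to compound 4 (0.50 log units; beyond the scatter), resting on the direction of a 5.0-fold higher number from compound 2 to compound 1 (0.70 log units; beyond the scatter). Compound 4 is therefore estimated at 80000 nM, between 30000 nM and 200000 nM.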

Compound 4, half-maximal inhibitory concentration: 5780 nM
Compound 4: middle estimate off by 14-fold (1.14 log units), on the high side, and the stated range ends above it.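

Methyl in place of phenyl on an amine nitrogen gave a 4.4-fold lower number from compound 3 to compound 4 (0.64 log units; beyond the scatter), so the direction seen on the other core did not carry over. Set side by side, the two steps run in opposite directions: the same change on two cores in this assay, a 5.0-fold higher number (0.70 log units; beyond the scatter) from compound 2 to compound 1 and a 4.4-fold lower number (0.64 log units; beyond the scatter) from compound 3 to compound 4, 22-fold (1.34 log units) apart, beyond the scatter of two such steps Across these four compounds, the outcome of this kind of change therefore depends on the core that carries it, but the two pairs do not show which difference between the cores is responsible, and they give no rule for predicting the step on a further core.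

The compounds shown leave open how a longer chain, such as propyl, or a benzyl group on this nitrogen would compare with methyl and phenyl. From the compounds shown here alone, whether either direction would hold on a third core also remains open.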